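This account rests on a few compounds, and the source may have more. Where it says the series, first, only, none or still open, it means among the compounds named here.

Working notes on the aryl group carried by the silicon in this series. The shared core is that of compound 1 `CCN(C/C=C/C#CC(C)(C)C)Cc1cccc(OC[Si](C)(C)c2ccc(Br)cc2)c1`, which in a functional assay on liver (Sus scrofa) for inhibition of squalene monooxygenase (Homo sapiens), using microsomes (on this read-out lower numbers stand for stronger inhibition and higher numbers for weaker inhibition), gives 210 nM, the lowest of the three numbers in hand. Compound 2 `CCN(C/C=C/C#CC(C)(C)C)Cc1cccc(OC[Si](C)(C)c2cccc(C)c2)c1` carries 3-methylphenyl in place of 4-bromophenyl on the silicon and gives 3000 nM in this assay, a step of a 14-fold higher number from compound 1 to compound 2 (1.15 log units; beyond the scatter). Compound 3 `CCN(C/C=C/C#CC(C)(C)C)Cc1cccc(OC[Si](C)(C)c2ccc(C(=O)C(F)(F)F)cc2)c1` carries (trifluoromethyl)carbonyl in place of bromo on an aromatic carbon and gives 5000 nM, a step of a 24-fold higher number from compound 1 to compound 3 (1.38 log units; beyond the scatter). Between the two alternatives the difference is a 1.7-fold higher number from compound 2 to compound 3 (0.22 log units; within the scatter).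

Compound 4 `CCN(C/C=C/C#CC(C)(C)C)Cc1cccc(OC[Si](C)(C)c2ccccc2-c2ccsc2)c1` is not yet measured. It differs from compound 1 as follows: 2-(thiophen-3-yl)phenyl in place of 4-bromophenyl on a silicon. Both measured departures from 4-bromophenyl on the silicon, a 14-fold higher number from compound 1 to compound 2 (1.15 log units; beyond the scatter) and a 24-fold higher number from compound 1 to compound 3 (1.38 log units; beyond the scatter), gave large steps toward higher numbers, so a step of similar size and direction is expected here, a 12-fold higher number from compound 1 to compound 4 (1.08 log units; beyond the scatter), though with the change this time adding a second ring the uncertainty is wide. In this assay compound 4 is therefore estimated at 2500 nM, between 500 nM and 10000 nM.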

Compound 4, half-maximal inhibitory concentration: 10000 nM
For compound 4 the middle estimate is 4.0-fold (0.60 log units) below the measured one; the range from low to high includes it.
By their numbers in this assay, from the lowest: compound 1; then compounds 2, 3 and 4 (each within the scatter of the next, the first and the last beyond it).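

In this assay, for the compounds shown here, 2-(thiophen-3-yl)phenyl, the only group on the silicon here that brings a second aromatic ring, also falls well short of 4-bromophenyl, with a 48-fold higher number from compound 1 to compound 4 (1.68 log units; beyond the scatter). This group also separates from 3-methylphenyl, with a 3.3-fold higher number from compound 2 to compound 4 (0.52 log units; beyond the scatter), a modest step beyond the scatter, whereas a 2.0-fold higher number from compound 3 to compound 4 (0.30 log units; within the scatter) stays within the scatter, so the three replacements do not all sit level with one another. No measurement on hand bears on the reason for these differences.

From the compounds shown here alone, it remains open whether 4-chlorophenyl or 4-methylphenyl on the silicon would stay near the value of compound 1, 210 nM. Also open, going by these compounds, is whether unsubstituted phenyl would fall with that compound or with the three weaker ones.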